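Working notes: from compound 3 to compound 4

This account rests on a few compounds, and the source may have more. Where it says the series, first, only, none or still open, it means among the compounds named here.

Values in a functional assay on HepG2 cells (Homo sapiens) for cytotoxicity, read by MTT assay, with a stated time of 24 h; a higher number here means a weaker inhibitor, a lower number a stronger inhibitor:
- compound 1 `CC[C@H](C)[C@@H](O)C(=O)O[C@@H](C(=O)O[C@@H](C(=O)O[C@@H](C(=O)O[C@@H](C(=O)OC[C@@H](O)[C@@H](O)[C@H](O)CO)[C@@H](C)CC)[C@@H](C)CC)[C@@H](C)CC)[C@@H](C)CC`: 29000 nM
- compound 2 `CC[C@H](C)[C@@H](O)C(=O)O[C@@H](C(=O)O[C@@H](C(=O)O[C@@H](C(=O)O[C@@H](C(=O)OC[C@@H](O)[C@@H](O)CO)[C@@H](C)CC)[C@@H](C)CC)[C@@H](C)CC)[C@@H](C)CC`: 28700 nM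
- compound 3 `CC[C@H](C)[C@@H](O)C(=O)O[C@@H](C(=O)O[C@@H](C(=O)O[C@@H](C(=O)O[C@@H](C(=O)O[C@@H]([C@H](O)[C@H](O)CO)[C@H](O)CO)[C@@H](C)CC)[C@@H](C)CC)[C@@H](C)CC)[C@@H](C)CC`: > 53200 nM (a limit)

Compound 3 gives no number on this read-out, and its entry is a limit. Its standing is the limit of > 53200 nM in this assay, at which 1 of the 3 values shown sits.

The next structure is compound 4 `CC[C@H](C)[C@@H](O)C(=O)O[C@@H](C(=O)O[C@@H](C(=O)O[C@@H](C(=O)O[C@@H](C(=O)O[C@H](CO)[C@@H](O)[C@H](O)[C@H](O)CO)[C@@H](C)CC)[C@@H](C)CC)[C@@H](C)CC)[C@@H](C)CC`, which has the same atoms as compound 3, joined differently. The change is 2,3,4,5-tetrahydroxy-1-(hydroxymethyl)pentyl in place of 1-(1,2-dihydroxyethyl)-2,3,4-trihydroxybutyl on an oxygen next to a carbonyl group. In words, 2,3,4,5-tetrahydroxy-1-(hydroxymethyl)pentyl stands in place of 1-(1,2-dihydroxyethyl)-2,3,4-trihydroxybutyl on an oxygen next to a carbonyl group.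

Within the data shown here, three measured steps bear on this change. Hydrogen in place of hydroxymethyl gives a 1.0-fold lower number from compound 1 to compound 2 (0.00 log units; within the scatter). The two steps into the group that leaves are an at least 1.8-fold higher number from compound 1 to compound 3 (0.26 log units; that floor lies within the scatter) and an at least 1.8-fold higher number from compound 2 to compound 3 (0.26 log units; that floor lies within the scatter). Both of these rest on a limit, and their floors lie within the scatter. Among the measured compounds shown here, no measured step in this assay therefore lies beyond the scatter, and none beyond the scatter is expected here. Compound 4 may also return only a limit.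

The expected step is an at least 1.0-fold lower number from compound 3 to compound 4 (0.02 log units; that floor lies within the scatter), which is not expected to lie beyond the scatter.

Compound 4 is expected at about 50000 nM, with an estimated range of 27000 nM to 90000 nM.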

Compound 4, half-maximal inhibitory concentration: 36200 nM
Compound 4: middle estimate off by 1.4-fold (0.14 log units), on the high side; the range from low to high includes it.
By their numbers in this assay, from the lowest: compounds 2, 1 and 4 (each within the scatter of the next). At a limit, above all of these: compound 3.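

In this assay, among these compounds, exchanging 1-(1,2-dihydroxyethyl)-2,3,4-trihydroxybutyl for its isomer 2,3,4,5-tetrahydroxy-1-(hydroxymethyl)pentyl on the oxygen next to a carbonyl group gives an at least 1.4-fold lower number from compound 3 to compound 4 (0.16 log units; that floor lies within the scatter), so this rearrangement of the same atoms yields a measured number but no step that can be read as beyond the scatter. The new group also falls alongside the two earlier groups, with a 1.3-fold higher number from compound 2 to compound 4 (0.10 log units; within the scatter) and a 1.2-fold higher number from compound 1 to compound 4 (0.10 log units; within the scatter), which now places three different polyhydroxylated chains on this oxygen within the scatter of one another in this assay. Compound 3 remains the only entry without a number, and its value is a limit: the limit of > 53200 nM in this assay, at which 1 of the 4 values shown sits.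

On these data alone, whether compound 3 truly differs from compound 4 stays open, since its limit sets only a floor that lies within the scatter. All the groups shown at this position are hydroxylated chains, so it remains open whether an amine, a carboxylic acid or an unhydroxylated longer alkyl chain on this oxygen would give a step beyond the scatter in this assay.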